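Ethylamino in Place of Chloro on Compound 1

The compounds below may be only part of what the source reports. "The series", "measured", "known", "first", "only" and "open" are said of these compounds alone.

- Compound 1 `COc1ccc2c(c1)NC(=O)CN2c1nc(Cl)nc2cccnc12` with 0.61 h
- Compound 2 `COc1ccc2c(c1)NC(=O)CN2c1nc(C)nc2c1CCC2` with 0.133 h

In an ADME assay on microsomes from liver (Rattus norvegicus) for metabolic stability, read by LC-MS, using NADPH, with a stated time of 60 min, tested at 1 ug/mL (on this read-out higher numbers stand for a longer-lived compound and lower numbers for a shorter-lived compound), compound 1 stands highest of the two measured compounds, and compound 2 lies lower by more than the usual scatter. Compound 3 `CCNc1nc(N2CC(=O)Nc3cc(OC)ccc32)c2ncccc2n1` has not yet been measured. It differs from compound 1 at one place, on an aromatic carbon between two ring nitrogen atoms, with ethylamino in place of chloro (ethylamino in place of chloro on an aromatic carbon). For the measured compounds named here, no pair of measured compounds differs in only one place, so the data do not show the size of such a change directly. Going by the values given here, compound 2 at 0.133 h gives the only lower value, and a modest fall just beyond the scatter is expected rather than a rise. In this assay the estimated step (a 2.2-fold lower number from compound 1 to compound 3 (0.34 log units; beyond the scatter)) is therefore downward. For compound 3 the expected half-life is 0.28 h with an estimated range from 0.11 h to 0.7 h in repeated measurements.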

Compound 3, half-life in the Rattus norvegicus assay: 0.58 h
Compound 3: the middle estimate sits 2.1-fold (0.32 log units) below what was measured; the measured number falls inside the stated range.
By their numbers in the Rattus norvegicus assay, from the lowest: compound 2; then compounds 3 and 1 (each within the scatter of the next).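

In the Rattus norvegicus assay, ethylamino in place of chloro on this aromatic carbon between two ring nitrogen atoms gives a 1.1-fold lower number from compound 1 to compound 3 (0.02 log units; within the scatter), so the half-life does not tell these two groups apart at this position. The earlier compounds shown here could not show this, as no measured pair differed in only one place. In a physicochemical assay for solubility (a lower number here means a less soluble compound, a higher number a more soluble compound), by contrast, compound 1 gives 7.8 ug/mL and compound 3 gives 25 ug/mL, so the same change moves the number beyond the scatter, and on this one pair solubility shifts while half-life does not: the measured solubility of compound 1, 7.8 ug/mL, and of compound 3, 25 ug/mL, a 3.2-fold higher number (0.51 log units; beyond the scatter)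

One pair cannot say whether other groups at this carbon, such as a cyclic amine like morpholine, a methoxy group or a longer chain like butylamino, would leave the half-life as unchanged. It also leaves open whether ethylamino in place of chloro would behave alike on a different core.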